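The source may hold more compounds than are shown below. What is called first, only, known or untested is meant among the compounds shown, and "the series" means these compounds.

Working notes on the series. Compound 1 `CN(C)CCn1cnnc1-c1cc(Oc2ccc(NC(=O)N/N=C/c3c(Cl)cccc3Cl)cc2F)ccn1` gives 160 nM in a functional assay on MKN-45 cells (Homo sapiens) for cytotoxicity, read by MTT assay, with a stated time of 72 h; on this read-out lower numbers stand for stronger inhibition and higher numbers for weaker inhibition. Compound 2 `COc1ccc(OC)c(/C=N/NC(=O)Nc2ccc(Oc3ccnc(-c4nncn4CCN(C)C)c3)c(F)c2)c1` gives 1510 nM; compound 3 `CN(C)CCn1cnnc1-c1cc(Oc2ccc(NC(=O)N/N=C/c3ccccc3O[N+](=O)[O-])cc2F)ccn1` gives 1020 nM, the second highest of the three numbers. The steps at the carbon with a double bond to nitrogen were a 9.4-fold higher number from compound 1 to compound 2 (0.97 log units; beyond the scatter), a 6.4-fold higher number from compound 1 to compound 3 (0.80 log units; beyond the scatter) and a 1.5-fold lower number from compound 2 to compound 3 (0.17 log units; within the scatter). Compound 4 `CN(C)CCn1cnnc1-c1cc(Oc2ccc(NC(=O)N/N=C/c3ccc(F)cc3)cc2F)ccn1` is not yet measured; the change is 4-fluorophenyl in place of 2-(nitrooxy)phenyl on a carbon with a double bond to nitrogen. Both measured steps ending at compound 3 bear on it: the swap from 2,6-dichlorophenyl moved the number well beyond the scatter, the swap from 2,5-dimethoxyphenyl did not. A 4-fluorophenyl is a new group, so a step downward toward compound 1 is expected but uncertain. The expected step is a 2.0-fold lower number from compound 3 to compound 4 (0.31 log units; beyond the scatter). Compound 4 is estimated at 500 nM, within 150 nM to 1600 nM, in this assay.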

Compound 4, half-maximal inhibitory concentration: 1030 nM
Compound 4: the middle estimate sits 2.1-fold (0.31 log units) below what was measured; measured number inside the range.
By their numbers in this assay, from the lowest: compound 1; then compounds 3, 4 and 2 (each within the scatter of the next).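

In this assay, 4-fluorophenyl shows no separation from the other two replacements on this carbon, with a 1.0-fold higher number from compound 3 to compound 4 (0.00 log units; within the scatter) and a 1.5-fold lower number from compound 2 to compound 4 (0.17 log units; within the scatter), while a 6.4-fold higher number from compound 1 to compound 4 (0.81 log units; beyond the scatter) leaves 2,6-dichlorophenyl alone apart from the rest. A halogen on the aromatic ring is therefore not enough by itself to match compound 1, as compound 4 carries fluorine. Nothing available explains this separation.

Still open, going by these compounds, is whether the two chlorines together are needed, or whether one chlorine would do. A 2-chlorophenyl, 4-chlorophenyl or unsubstituted phenyl group on this carbon would test that.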